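Tosyl for sorbamide on a threonine octadecylamide

The compounds below may be only part of what the source reports. "The series", "measured", "known", "first", "only" and "open" are said of these compounds alone.

In a functional assay on HepG2 cells (Homo sapiens) for cytotoxicity, read by MTT assay, with a stated time of 48 h (on this read-out lower numbers stand for stronger inhibition and higher numbers for weaker inhibition), the measured compounds give the following numbers.

Compound 1 `C/C=C/C=C/C(=O)N[C@H](C(=O)NCCCCCCCCCCCC)[C@@H](C)O` gives > 400000 nM, which is a limit of the assay rather than a number.
Compound 2 `CCCCCCCCCCCCNC(=O)[C@@H](NS(=O)(=O)c1ccc(C)cc1)[C@@H](C)O` gives 25800 nM.
Compound 3 `C/C=C/C=C/C(=O)N[C@H](C(=O)NCCCCCCCCCCCCCCCCCC)[C@@H](C)O` gives 284000 nM.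

Compound 1 and compound 2 differ by (4-methylphenyl)sulfonyl in place of (penta-1,3-dien-1-yl)carbonyl on an amine nitrogen. Across this change the read-out moves by an at least 15-fold lower number from compound 1 to compound 2 (1.19 log units; beyond the scatter), and the size of that step can only be stated as a floor because of the limit of > 400000 nM in this assay, at which 1 of the 3 values shown sits. Compound 1 and compound 3 differ by hexyl in place of hydrogen on a saturated chain carbon, ten or more bonds along the chain from an amide-type nitrogen; the step here is an at least 1.4-fold lower number from compound 1 to compound 3 (0.14 log units; that floor lies within the scatter), and since it begins at a limit the two values cannot be ordered. Compound 3 stands farthest from compound 2 among the numbers that are not limits.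

Compound 4 `CCCCCCCCCCCCCCCCCCNC(=O)[C@@H](NS(=O)(=O)c1ccc(C)cc1)[C@@H](C)O` has not been measured. It differs from compound 3 by (4-methylphenyl)sulfonyl in place of (penta-1,3-dien-1-yl)carbonyl on an amine nitrogen, the same change that turns compound 1 into compound 2, at the same place on both cores. The cores of compound 3 and compound 4 carry the longer chain described under (hexyl in place of hydrogen on a saturated chain carbon, ten or more bonds along the chain from an amide-type nitrogen).

Compound 4 is therefore expected to sit well below compound 3, with the expected step being a 14-fold lower number from compound 3 to compound 4 (1.15 log units; beyond the scatter), resting on the step of an at least 15-fold lower number from compound 1 to compound 2 (1.19 log units; beyond the scatter) seen on the shorter-chain core and on the near-equality of compound 1 and compound 3 shown by an at least 1.4-fold lower number from compound 1 to compound 3 (0.14 log units; that floor lies within the scatter). Compound 4 is estimated at 20000 nM, between 6000 nM and 70000 nM.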

Compound 4, half-maximal inhibitory concentration: 75800 nM
Estimate against measurement, compound 4: 3.8-fold (0.58 log units) below; measured number outside the range, above it.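

In this assay, (4-methylphenyl)sulfonyl in place of (penta-1,3-dien-1-yl)carbonyl on the amine nitrogen again lowers the number on the longer-chain core, a 3.7-fold lower number from compound 3 to compound 4 (0.57 log units; beyond the scatter), so the direction of the change carries over, but its size does not match the step on the shorter-chain core: the same change on two cores in this assay, an at least 15-fold lower number (1.19 log units; beyond the scatter) from compound 1 to compound 2 and a 3.7-fold lower number (0.57 log units; beyond the scatter) from compound 3 to compound 4, at least 4.1-fold (0.61 log units) apart, beyond the scatter of two such steps. The longer chain does not behave alike on the two cores either, for with (4-methylphenyl)sulfonyl on the nitrogen it gives a 2.9-fold higher number from compound 2 to compound 4 (0.47 log units; beyond the scatter), and that step stands apart from the one seen with (penta-1,3-dien-1-yl)carbonyl: the same change on two cores in this assay, an at least 1.4-fold lower number (0.14 log units; that floor lies within the scatter) from compound 1 to compound 3 and a 2.9-fold higher number (0.47 log units; beyond the scatter) from compound 2 to compound 4, at least 4.1-fold (0.61 log units) apart, beyond the scatter of two such steps. Compound 1 sits at a limit of the assay and not at a number, so the data give only a floor for how far these steps part, and they do not show why they part: the limit of > 400000 nM in this assay, at which 1 of the 4 values shown sits.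

The compounds shown leave open whether the step shrinks steadily as the chain grows, which a tetradecyl chain or a still shorter chain on the same cores could test. They also leave open whether the change in the number belongs to the sulfonyl group or to its aromatic ring, which a methylsulfonyl group on the same nitrogen could separate.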